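From 4-chlorophenyl to 2-fluorophenyl on the shared core

A few compounds are considered here, and "the series" means these few. Any claim that something is new, unique, unknown or untested is made for them only; others in the source may bear on it.

In a functional assay on B16-F10 cells (Mus musculus) for antiproliferative activity, read by MTT assay, with a stated time of 48 h (on this read-out higher numbers stand for weaker inhibition and lower numbers for stronger inhibition), compound 1 `CC(=O)N1N=C(c2ccc3ccccc3c2)OC1c1ccc(Br)cc1` gives 4.68 ug/mL and compound 2 `CC(=O)N1N=C(c2ccc3ccccc3c2)OC1c1ccc(Cl)cc1` gives 2.48 ug/mL on the same read-out. Among the measured compounds shown here, these are the only two numbers so far, and compound 2 stands within the scatter of compound 1 (a 1.9-fold lower number from compound 1 to compound 2 (0.28 log units; within the scatter)) for chloro in place of bromo on an aromatic carbon.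

Compound 3 `CC(=O)N1N=C(c2ccc3ccccc3c2)OC1c1ccccc1F` has not yet been measured. It carries 2-fluorophenyl in place of 4-chlorophenyl on a saturated ring carbon of the shared core. For the measured compounds named here, the step from compound 1 to compound 2 is the only measured one that bears on this change, and it covers only part of it, as no measured compound carries 2-fluorophenyl. With that single step inside the scatter, no step beyond the scatter is expected in this assay and no direction can be assigned, although the uncovered change calls for a wide range.

The estimated step is a 1.2-fold higher number from compound 2 to compound 3 (0.08 log units; within the scatter) and is expected to stay small. For compound 3 the estimated value is 3 ug/mL with an expected range from 1.1 ug/mL to 9 ug/mL in this series.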

Compound 3, half-maximal inhibitory concentration: 6.05 ug/mL
Estimate against measurement, compound 3: 2.0-fold (0.30 log units) below, and the stated range covers the measured number.
By their numbers in this assay, from the lowest: compounds 2, 1 and 3 (each within the scatter of the next, the first and the last beyond it).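

In this assay, among the compounds shown here, the exchange of 4-chlorophenyl for 2-fluorophenyl on the saturated ring carbon gives a 2.4-fold higher number from compound 2 to compound 3 (0.39 log units; beyond the scatter) and is the first step to pass beyond the scatter, which shows that the aryl group at this position can move the read-out, if only modestly. The exchange of 4-bromophenyl for 2-fluorophenyl gives a 1.3-fold higher number from compound 1 to compound 3 (0.11 log units; within the scatter) and stays within the scatter, so the aryl change does not separate every pair, and only compound 2 and compound 3 stand apart on this read-out. No measurement on hand gives a reason for either step.

Both steps alter the halogen and its place on the phenyl ring together, so the compounds shown cannot say which of the two carries the difference between compound 2 and compound 3. Also open, going by these compounds, is how this position responds to an unsubstituted phenyl or to a phenyl bearing a methoxy group, an amine or a carboxylic acid, and whether the acetyl group on the shared core tolerates a longer chain.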